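From isopropyl to 3-hydroxypropoxy on the shared core

The compounds below may be only part of what the source reports. "The series", "measured", "known", "first", "only" and "open" are said of these compounds alone.

Compound 1 `CCOC(=O)c1c(C)nc(-c2cccc(C#N)c2)n1O` gives 17600 nM
Compound 2 `CCOC(=O)c1c(C)nc(-c2ccccc2)n1OC` gives > 30000 nM (a limit, not a number)
Compound 3 `CCOC(=O)c1c(C)nc(-c2cccc(C#N)c2)n1C(C)C` gives 9260 nM

All three readings come from one test (a functional assay on a cell-free system (plasma, Oryctolagus cuniculus) for inhibition, with stated times of 5 min, 1 min and 6 min; on this read-out higher numbers stand for weaker inhibition and lower numbers for stronger inhibition). Only compound 1 and compound 3 have actual numbers, and the two cannot be told apart (a 1.9-fold lower number from compound 1 to compound 3 (0.28 log units; within the scatter)). Among the measured compounds shown here, for compound 2 only a limit exists (the limit of > 30000 nM in this assay, at which 1 of the 3 values shown sits), and it forms no measured step with the others.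

Compound 4 `CCOC(=O)c1c(C)nc(-c2cccc(C#N)c2)n1OCCCO` has yet to be measured. Compared with compound 3, it has 3-hydroxypropoxy in place of isopropyl on an aromatic nitrogen. For the measured compounds named here, only one measured step changes the group on that nitrogen (a 1.9-fold lower number from compound 1 to compound 3 (0.28 log units; within the scatter)). A single step is a thin guide, but it stayed within the scatter. A change no larger than the scatter is therefore expected in this assay, perhaps toward a somewhat higher number. The expected change is a 1.4-fold higher number from compound 3 to compound 4 (0.15 log units; within the scatter). For compound 4 the estimate is 13000 nM, with an expected range of 5000 nM to 30000 nM.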

Compound 4, half-maximal inhibitory concentration: 11400 nM
Estimate against measurement, compound 4: 1.1-fold (0.06 log units) above, within the range that was stated.
By their numbers in this assay, from the lowest: compounds 3, 4 and 1 (each within the scatter of the next). At a limit, above all of these: compound 2.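

In this assay, replacing isopropyl with the longer 3-hydroxypropoxy on the aromatic nitrogen leaves the reading within the scatter (a 1.2-fold higher number from compound 3 to compound 4 (0.09 log units; within the scatter)). Placing 3-hydroxypropyl in place of hydrogen on the oxygen of compound 1 also stays within the scatter (a 1.5-fold lower number from compound 1 to compound 4 (0.19 log units; within the scatter)), so capping that hydroxy group with a chain gives no measurable shift. This position has now carried hydroxy, isopropyl and 3-hydroxypropoxy on the shared core, and compounds 1, 3 and 4 all lie within the scatter of one another, which a single step could not show.

Still open, from the compounds shown here alone, is whether an amine or a carboxylic acid at the end of the chain, or a much longer chain, would move the number beyond the scatter. Nothing measured here bears on why these three readings stay so close.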